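A Fluoro on the Benzyl Group of Compound 3

A few compounds are considered here, and "the series" means these few. Any claim that something is new, unique, unknown or untested is made for them only; others in the source may bear on it.

Three compounds measured in an ADME assay on HEK-293T cells (Homo sapiens) for inhibition, read by CCK-8 assay, with a stated time of 48 h, tested at 20 uM (on this read-out lower numbers stand for less inhibition of growth and higher numbers for more inhibition of growth at the one concentration tested), so far
Compound 1 `N#C/C(=C\c1ccccc1OS(=O)(=O)c1ccc([N+](=O)[O-])cc1)C(=O)Nc1nnc(Cc2ccccc2)s1` gives "not toxic" (no number reported)
Compound 2 `N#C/C(=C\c1ccccc1OS(=O)(=O)c1ccccc1[N+](=O)[O-])C(=O)Nc1nnc(Cc2ccccc2)s1` gives 10%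
Compound 3 `N#C/C(=C\c1ccccc1OS(=O)(=O)c1ccc(F)cc1)C(=O)Nc1nnc(Cc2ccccc2)s1` gives 6%

Compound 3 (6%) lies within the scatter of compound 2 (10%), and compound 1 adds no number. Compound 4 `N#C/C(=C\c1ccccc1OS(=O)(=O)c1ccc(F)cc1)C(=O)Nc1nnc(Cc2ccc(F)cc2)s1` turns benzyl into 4-fluorobenzyl, with fluoro in place of hydrogen on an aromatic carbon. Within the data shown here, no measured step touches that group. Among the measured compounds shown here, the only step available (a number 4 percentage points lower from compound 2 to compound 3 (within the scatter)) changes the group on the sulfonyl sulfur, so it offers just indirect guidance, and no change beyond the scatter is expected in this assay. The estimated step is small (a number 2 percentage points higher from compound 3 to compound 4 (within the scatter)). For compound 4 the expected value is 8%, within an estimated range from 0% to 22%.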

Compound 4, percent growth inhibition at one concentration: "not toxic" (no number reported)
For compound 4 the study gives words and no number, so the estimate cannot be set against anything.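

Compound 4 is reported as "not toxic" (no number reported) and so gives no readable step from compound 3. On these data alone, what 4-fluorobenzyl in place of benzyl does to the number in this assay stays open, and nothing available bears on this result.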